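Replacing the cycloheptyl group beside the ether oxygen

A few compounds are considered here, and "the series" means these few. Any claim that something is new, unique, unknown or untested is made for them only; others in the source may bear on it.

Three compounds share a core and differ in the chain bearing the acid or in the ring next to the ether oxygen. In a functional assay on the whole organism for inhibition, with Rattus norvegicus as the target (a lower number here means that less compound is needed, a higher number that more compound is needed for the effect), compound 1 `C/C(CCCC(=O)O)=N\OC(c1ccc(OCc2ccc3ccccc3n2)cc1)C1CCCCC1` gives 3 mg/kg, compound 2 `CC(/C=C/C(=O)O)=N\OC(c1ccc(OCc2ccc3ccccc3n2)cc1)C1CCCCC1` gives 2 mg/kg, and compound 3 `C/C(=N\OC(c1ccc(OCc2ccc3ccccc3n2)cc1)C1CCCCCC1)C(=O)O` gives 0.7 mg/kg, the lowest number of the three. Among the compounds with values here, the only measured step, a 1.5-fold lower number from compound 1 to compound 2 (0.18 log units; within the scatter), changes the acid chain, not the ring at the ether carbon, so it does not bear on the next change. Compound 4 `C/C(=N\OC(CC(C)(C)c1ccccc1)c1ccc(OCc2ccc3ccccc3n2)cc1)C(=O)O` carries 2-methyl-2-phenylpropyl in place of cycloheptyl on a saturated chain carbon bound to an aromatic carbon and an oxygen. Within the data shown here, no measured step touches this position, so the expectation rests on compound 3 alone, with a wide range. Compound 4 is estimated at 1 mg/kg, between 0.3 mg/kg and 3 mg/kg, which means an expected step of a 1.4-fold higher number from compound 3 to compound 4 (0.15 log units; within the scatter).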

Compound 4, dose for half-maximal effect: 2 mg/kg
Beside the measured number, compound 4's estimate is 2.0-fold (0.30 log units) below it; the measured number falls inside the stated range.
By their numbers in this assay, from the lowest: compound 3; then compounds 2, 4 and 1 (each within the scatter of the next).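

Within the data shown here, this is the first measured change at this position, on a saturated chain carbon bound to an aromatic carbon and an oxygen. In this assay, putting 2-methyl-2-phenylpropyl in place of cycloheptyl gives a 2.9-fold higher number from compound 3 to compound 4 (0.46 log units; beyond the scatter), a modest step showing that more compound is needed, yet a larger group with a six-membered aromatic ring remains compatible with activity. No available evidence accounts for this shift.

This single step changes ring type and group size together, so their contributions cannot be separated. On these data alone, how a benzyl group or a ring carrying an amine would behave at this position remains open.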